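Sulfonamide-capped glutamyl peptides as matrilysin inhibitors

The source may report more compounds than this note shows. Statements on the series, on what has been measured and on what is new or still open speak of the compounds shown alone.

Measured so far:
compound 1, `CSCC[C@H](NC(=O)[C@H](CC(C)C)NC(=O)[C@H](CO)NC(=O)CC[C@H](NS(=O)(=O)c1ccc(Cl)c(C(F)(F)F)c1)C(=O)O)C(N)=O`, 5700 nM
compound 2, `CC(C)C[C@H](NC(=O)CNC(=O)CC[C@H](NS(=O)(=O)c1ccc(Cl)c(C(F)(F)F)c1)C(=O)O)C(=O)N[C@H](C(=O)N[C@@H](C)C(N)=O)C(C)C`, 16 nM
compound 3, `O=C(O)[C@H](CCc1ccccc1)NS(=O)(=O)c1ccc(Cl)c(C(F)(F)F)c1`, 6100 nM

In an assay on isolated protein for inhibition of Matrilysin (Homo sapiens), read by fluorescence, with a stated time of 15 min (a lower number here means a stronger inhibitor, a higher number a weaker inhibitor), compound 2 gives the lowest number of the three. Compound 1 gives 5700 nM and compound 3 gives 6100 nM; both gaps to compound 2 lie well beyond the scatter, so compound 2 is the strongest inhibitor of the measured set. Going by the values given here, no pair of the measured compounds differs in one place only, so no single step has been measured.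

Compound 4, `CC(C)C[C@H](NC(=O)CNC(=O)CC[C@H](NS(=O)(=O)c1ccc(Cl)c(C(F)(F)F)c1)C(=O)O)C(=O)N[C@H](C(=O)N1CCC[C@H]1CC(N)=O)C(C)C`, is built from compound 2 by the change (2-(carbamoylmethyl)pyrrolidin-1-yl in place of (1-carbamoylethyl)amino on a carbonyl carbon). The position is the carbonyl carbon whose other neighbour is a saturated chain carbon, at the far end of the chain from the sulfonamide. Nothing in the measured set bears on this kind of exchange, so the direction of the step is open. In this assay a step of a 2.2-fold higher number from compound 2 to compound 4 (0.34 log units; beyond the scatter) is expected, leaning toward a slightly weaker inhibitor but not far beyond the scatter. For compound 4 in this assay the expected value is 35 nM, with a range from 8 nM to 150 nM.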

Compound 4, half-maximal inhibitory concentration: 10 nM
Estimate against measurement, compound 4: 3.5-fold (0.54 log units) above; the range from low to high includes it.
By their numbers in this assay, from the lowest: compounds 4 and 2 (each within the scatter of the next); then compounds 1 and 3 (each within the scatter of the next).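

In this assay, going by these compounds alone, 2-(carbamoylmethyl)pyrrolidin-1-yl in place of (1-carbamoylethyl)amino on a carbonyl carbon gives a 1.6-fold lower number from compound 2 to compound 4 (0.20 log units; within the scatter), the only single-place step so far, so the two compounds cannot be told apart at this position. The entering group brings one five-membered non-aromatic ring, 9 heavy atoms against 6 and 1 hydrogen-bond donor against 2, and this position accepts that exchange with the number still in the low range set by compound 2 at 16 nM. Nothing available gives a reason for this outcome.

The compounds shown leave open whether the terminal carbamoyl group is needed at all, since every group at this position carries one. A carboxylic acid, a nitrile or an amine in its place would address that, as would a longer chain carrying the carbamoyl group on the pyrrolidine ring.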